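Replacing a Hydroxy Group with a Pyridinylamine: What to Expect

This account rests on a few compounds, and the source may have more. Where it says the series, first, only, none or still open, it means among the compounds named here.

Measured so far:
compound 1 `N#Cc1c(O)nc(SCc2nc3ccccc3[nH]2)nc1-c1ccccc1` gives 6.09 nM
compound 2 `N#Cc1c(Cl)nc(SCc2nc3ccccc3[nH]2)nc1-c1ccccc1` gives 4.38 nM

Both compounds share one core and were tested in a functional assay on RKOp27 cells (Homo sapiens) for cytotoxicity, read by MTT assay, with a stated time of 3 days; on this read-out higher numbers stand for weaker inhibition and lower numbers for stronger inhibition. For the measured compounds named here, compound 1 has the highest of the two numbers, and the single measured step, a 1.4-fold lower number from compound 1 to compound 2 (0.14 log units; within the scatter), comes from swapping the hydroxy group for a chloro group on an aromatic carbon.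

Compound 3 `N#Cc1c(Nc2ccccn2)nc(SCc2nc3ccccc3[nH]2)nc1-c1ccccc1` has not yet been measured. Compared with compound 1 it carries a much larger replacement at the same carbon: (pyridin-2-yl)amino in place of hydroxy on an aromatic carbon. Going by the values given here, the only measured step, a 1.4-fold lower number from compound 1 to compound 2 (0.14 log units; within the scatter), stayed within the scatter and concerns a different, smaller group, so it offers no direct guide for this change; nothing in the data points in either direction. Compound 3 is therefore expected to show a 1.1-fold lower number from compound 1 to compound 3 (0.04 log units; within the scatter), that is, no shift beyond the scatter. The estimate for compound 3 is 5.5 nM, expected to lie between 1.5 nM and 20 nM.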

Compound 3, half-maximal inhibitory concentration: 3.8 nM
For compound 3 the middle estimate is 1.4-fold (0.16 log units) above the measured one, and the stated range covers the measured number.
By their numbers in this assay, from the lowest: compounds 3, 2 and 1 (each within the scatter of the next).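

In this assay, this position accepts a far larger group with no shift beyond the scatter: the change gives a 1.6-fold lower number from compound 1 to compound 3 (0.20 log units; within the scatter), and replacing chloro instead gives a 1.2-fold lower number from compound 2 to compound 3 (0.06 log units; within the scatter). The earlier swap exchanged only hydroxy for chloro, whereas (pyridin-2-yl)amino brings 7 heavy atoms and a six-membered aromatic ring in place of the single oxygen of hydroxy, so even this much added bulk leaves the number within the scatter. No evidence here explains why these three groups give such similar numbers.

Still open, as far as these compounds go, is whether the ring of (pyridin-2-yl)amino matters at all, or only the nitrogen attached to the core, and a plain amine at the same carbon would separate the two. Also open, from the compounds shown here alone, is whether a carboxylic acid or a longer chain here would move the number beyond the scatter.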